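Replacing the sulfonyl arm of compound 2 with a pyrrolidinyl carbonyl

The source may hold more compounds than are shown below. What is called first, only, known or untested is meant among the compounds shown, and "the series" means these compounds.

Three compounds share one core, and their behaviour in a physicochemical assay for solubility (a lower number here means a less soluble compound, a higher number a more soluble compound), is known. Compound 1 `O=C(c1ccccn1)N1CCC(NS(=O)(=O)c2cc(S(=O)(=O)c3ccccc3)ccc2C(F)(F)F)CC1` gives 100000 nM in this assay. Compound 2 `O=C(O)c1ccc(S(=O)(=O)N2CCC(NS(=O)(=O)c3cc(S(=O)(=O)c4ccccc4)ccc3C(F)(F)F)CC2)cc1` gives 12500 nM, the lowest of the three numbers: compound 1 stands a step above it, as does compound 3 `O=S(=O)(NC1CCN(S(=O)(=O)c2cccc(-c3nnn[nH]3)c2)CC1)c1cc(S(=O)(=O)c2ccccc2)ccc1C(F)(F)F`, which gives 100000 nM. The measured steps are an 8.0-fold lower number from compound 1 to compound 2 (0.90 log units; beyond the scatter) and an 8.0-fold higher number from compound 2 to compound 3 (0.90 log units; beyond the scatter).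

Compound 4 `O=C([C@@H]1CCNC1)N1CCC(NS(=O)(=O)c2cc(S(=O)(=O)c3ccccc3)ccc2C(F)(F)F)CC1` has not yet been measured. Its difference from compound 2 is (pyrrolidin-3-yl)carbonyl in place of (4-carboxyphenyl)sulfonyl on an amine nitrogen in a ring. The change brings back a carbonyl on the ring nitrogen, the same kind of link that compound 1 carries, and compound 1 sits a modest step above compound 2 because of an 8.0-fold lower number from compound 1 to compound 2 (0.90 log units; beyond the scatter). On that basis a modest rise in this assay is expected, of a size close to that measured step, taking compound 4 back toward the level shared by compound 1 and compound 3. Compound 4 is therefore estimated at 100000 nM, within 30000 nM to 300000 nM, a step of an 8.0-fold higher number from compound 2 to compound 4 (0.90 log units; beyond the scatter) that is expected rather than known.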

Compound 4, solubility: 12500 nM
Beside the measured number, compound 4's estimate is 8.0-fold (0.90 log units) above it; the measured number lies below the stated range.
By their numbers in this assay, from the lowest: compounds 2 and 4 (each within the scatter of the next); then compounds 1 and 3 (each within the scatter of the next).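

In this assay, the carbonyl link on the ring nitrogen does not by itself set the level: the swap of (4-carboxyphenyl)sulfonyl for (pyrrolidin-3-yl)carbonyl gives no change at the digits printed from compound 2 to compound 4 (within the scatter) while pyrrolidin-3-yl in place of pyridin-2-yl on the carbonyl carbon gives an 8.0-fold lower number from compound 1 to compound 4 (0.90 log units; beyond the scatter) with the link unchanged. The number at this position therefore follows the group carried on the carbonyl, at least across compound 1 and compound 4, and not the carbonyl alone. Nothing measured here explains these numbers.

The compounds shown leave open whether a phenyl on the carbonyl carbon would stand with compound 1 or with compound 4. They also leave open whether the ring nitrogen of the pyrrolidin-3-yl matters, which a cyclopentyl on the carbonyl carbon could test.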